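A few compounds are considered here, and "the series" means these few. Any claim that something is new, unique, unknown or untested is made for them only; others in the source may bear on it.

Measured so far in an in vivo ADME assay on the whole organism for metabolic stability, with Homo sapiens as the target, read by LC-MS, at a dose of 160 mg/kg by the oral route; a lower number here means that the compound disappears faster, a higher number that the compound lasts longer:
compound 1, `CN1CC(=O)N=C1N/C(=N\C(=O)OC(C)(C)C)Nc1ccc(Cl)c(Cl)c1`, < 0.167 h
compound 2, `CC(C)N1CC(=O)N=C1N/C(=N\C(=O)OC(C)(C)C)Nc1ccc(Cl)c(Cl)c1`, 0.213 h

Compound 1 reaches only a limit of this assay at < 0.167 h, so it reports no number of its own. Within the data shown here, compound 2 gives 0.213 h in this assay, and that is the only actual number in the set. The other entry, from compound 1, is a limit. The measured step of an at least 1.2-fold higher number from compound 1 to compound 2 (0.10 log units; that floor lies within the scatter) is known only as a floor because compound 1 sits at the limit of < 0.167 h in this assay, at which 1 of the 2 values shown sits, and that floor lies within the usual scatter.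

Compound 3, `CC(C)(C)OC(=O)/N=C(\NC1=NC(=O)CN1C(C)(C)C)Nc1ccc(Cl)c(Cl)c1`, has not been measured. It differs from compound 2 by methyl in place of hydrogen on a saturated chain carbon bound to an amine nitrogen in a ring and two saturated chain carbons. Among the measured compounds shown here, the one measured step that bears on it is the same kind of enlargement on the same amine nitrogen, an at least 1.2-fold higher number from compound 1 to compound 2 (0.10 log units; that floor lies within the scatter), which gave at most a gain too small to separate from scatter. On that basis compound 3 is expected to shift by a 1.3-fold higher number from compound 2 to compound 3 (0.12 log units; within the scatter), a change that would not exceed the scatter. The estimate for compound 3 in this assay is 0.28 h, expected to fall between 0.15 h and 0.55 h.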

Compound 3, half-life: < 0.167 h
Compound 3: a limit, no number; the forecaster's own chance of this, stated with the estimate: 20%; middle value at least 1.6-fold (0.22 log units) from the limit.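

In this assay, methyl in place of hydrogen on a saturated chain carbon bound to an amine nitrogen in a ring gives an at least 1.2-fold lower number from compound 2 to compound 3 (0.10 log units; that floor lies within the scatter), so enlarging the group on this nitrogen from isopropyl to tert-butyl does not carry the half-life to a readable higher number, and this floor does not separate the change from scatter. The entry for compound 3 is a limit of the assay and not a number. With this result, compound 2 remains the only compound with a number of its own, while the methyl and tert-butyl compounds both stand at a limit: the limit of < 0.167 h in this assay, at which 2 of the 3 values shown sit.

Going by these compounds, the step from compound 1 to compound 3 cannot be read, which leaves methyl and tert-butyl on this nitrogen unranked, and the true size of the step to compound 3 also stays open. The compounds shown also leave open whether an ethyl or a cyclopropyl group on the same nitrogen would give a readable half-life in this assay, and how it would compare with the isopropyl of compound 2.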